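This account rests on a few compounds, and the source may have more. Where it says the series, first, only, none or still open, it means among the compounds named here.

Compound 2 `COc1ccc(C(=O)/C=C/c2cc(-c3cc(OC)c(OC)c(OC)c3)n[nH]2)cc1` gives 6060 nM in a functional assay on COLO 205 cells (Homo sapiens) for inhibition, read by sulforhodamine B assay, with a stated time of 48 h; a lower number here means that less compound is tolerated, a higher number that more compound is tolerated; compound 1 `COc1ccc(C(=O)/C=C/c2cc(-c3cc(OC)c(OC)c(OC)c3)n[nH]2)cc1OC` gives 5920 nM in this assay, and the two sit within the scatter of each other, the step of a 1.0-fold higher number from compound 1 to compound 2 (0.01 log units; within the scatter) showing nothing beyond it. Compound 3 `COc1cc(-c2cc(/C=C/C(=O)c3ccc(F)c(F)c3)[nH]n2)cc(OC)c1OC` differs from compound 2 by 3,4-difluorophenyl in place of 4-methoxyphenyl on a carbonyl carbon. Going by the values given here, no measured step bears on an exchange of the 4-methoxyphenyl as a whole; the one step known, removing a methoxy, was flat. The step to compound 3 is therefore expected to be small, a 1.0-fold lower number from compound 2 to compound 3 (0.00 log units; within the scatter), with wide uncertainty. Compound 3 is estimated at 6000 nM in this assay, between 2400 nM and 15000 nM.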

Compound 3, concentration lethal to 50% of the cells: 6000 nM
The estimate for compound 3 equals the measured number at the digits printed; the range from low to high includes it.
By their numbers in this assay, from the lowest: compounds 1, 3 and 2 (each within the scatter of the next).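

In this assay the exchange of the whole aryl group on a carbonyl carbon gives a 1.0-fold lower number from compound 2 to compound 3 (0.00 log units; within the scatter) and a 1.0-fold higher number from compound 1 to compound 3 (0.01 log units; within the scatter) and so stays within the scatter, as removing one methoxy did. The earlier pair touched a single methoxy, whereas here every methoxy on this ring gives way to fluorine and the numbers stay level. No measurement available here bears on why this position is so flat. Open, as far as these compounds go, is whether a basic amine or a carboxylic acid on this ring would stay equally flat, and whether an unsubstituted phenyl would.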